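Swapping 4-Bromophenyl for 3-Bromophenyl on the Amide

A few compounds are considered here, and "the series" means these few. Any claim that something is new, unique, unknown or untested is made for them only; others in the source may bear on it.

In a functional assay on MDA-MB-231 cells (Homo sapiens) for antiproliferative activity, read by MTT assay, with a stated time of 72 h (on this read-out lower numbers stand for stronger inhibition and higher numbers for weaker inhibition), compound 1 (`O=C(CCc1cccc2c1B(O)OC2)Nc1nccs1`), with 1,3-thiazol-2-yl on the amide-type nitrogen, reads > 100000 nM as a limit of the assay and not a number. Compound 2 (`O=C(CCc1cccc2c1B(O)OC2)Nc1ccc(Cl)cc1`), with 4-chlorophenyl at that place, gives 3600 nM and compound 3 (`O=C(CCc1cccc2c1B(O)OC2)Nc1ccc(Br)cc1`), with 4-bromophenyl, gives 5300 nM as a measured number. Both replacements of the 1,3-thiazol-2-yl group are large steps, with an at least 27-fold lower number from compound 1 to compound 2 (1.44 log units; beyond the scatter) and an at least 18-fold lower number from compound 1 to compound 3 (1.27 log units; beyond the scatter) on record. Compound 3 has only compound 2 as a numerical reference, and a 1.5-fold higher number from compound 2 to compound 3 (0.17 log units; within the scatter) lies within the scatter, so the two cannot be told apart.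

Compound 4 (`O=C(CCc1cccc2c1B(O)OC2)Nc1cccc(Br)c1`) has 3-bromophenyl in place of 4-bromophenyl on an amide-type nitrogen, so the same atoms are joined differently. Among the measured compounds shown here, no measured step moves a group around the phenyl ring. The two large steps exchange the whole ring and bear only loosely on this one, while the halogen exchange (a 1.5-fold higher number from compound 2 to compound 3 (0.17 log units; within the scatter)) stayed within the scatter. Compound 4 keeps a bromophenyl group, so a measurable number is expected, as for compound 3 (5300 nM), rather than a limit. No move beyond the scatter is expected in either direction (estimated: a 1.1-fold higher number from compound 3 to compound 4 (0.05 log units; within the scatter)). The estimated value for compound 4 is 6000 nM (expected range 2500 nM to 14000 nM).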

Compound 4, half-maximal inhibitory concentration: 720 nM
Estimate against measurement, compound 4: 8.3-fold (0.92 log units) above; the whole stated range lies above it.
By their numbers in this assay, from the lowest: compound 4; then compounds 2 and 3 (each within the scatter of the next). At a limit, above all of these: compound 1.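

In this assay, where the halogen sits on the phenyl ring matters more than which halogen it is among these compounds: with the same atoms joined differently, 3-bromophenyl in place of 4-bromophenyl gives a 7.4-fold lower number from compound 3 to compound 4 (0.87 log units; beyond the scatter), whereas bromo in place of chloro gave only a 1.5-fold higher number from compound 2 to compound 3 (0.17 log units; within the scatter). Compound 4 also separates from the other two compounds, with a 5.0-fold lower number from compound 2 to compound 4 (0.70 log units; beyond the scatter) and an at least 130-fold lower number from compound 1 to compound 4 (2.14 log units; beyond the scatter), so it has the lowest number of the series, with its steps to all the others beyond the scatter. Compound 1 is a limit of the assay and not a number, so the last of these steps is a bound and not an exact size: the limit of > 100000 nM in this assay, at which 1 of the 4 values shown sits.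

The compounds shown leave open whether chloro in place of the bromo of compound 4 would keep this lower number, which would show whether the gain belongs to the place alone or to bromo at that place. They also leave open what a methoxy group or a nitrile would give in place of that bromo, and nothing here gives a cause for the step.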